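The compounds below may be only part of what the source reports. "The series", "measured", "known", "first", "only" and "open" are said of these compounds alone.

Compound 1 `Cc1ccccc1-c1nnc(N(N)C(C)C)s1` gives 49 mg/kg in a functional assay on the whole organism with Mus musculus as the target, with a stated time of 1 h; a lower number here means that less compound is needed, a higher number that more compound is needed for the effect. Compound 2 `CC(C)N(N)c1nnc(-c2ccccc2Cl)s1` reaches only the limit > 100 mg/kg in this assay, so its result is not a number. That gap appears in the step of an at least 2.0-fold higher number from compound 1 to compound 2 (0.30 log units; that floor lies within the scatter), made by the change (chloro in place of methyl on an aromatic carbon). Compound 3 `Cc1ccccc1-c1nnc(NNC(C)C)s1` gives 54 mg/kg in this assay; its core differs from that of compound 1 by (isopropylamino)amino in place of amino(isopropyl)amino on an aromatic carbon, and the step of a 1.1-fold higher number from compound 1 to compound 3 (0.04 log units; within the scatter) is small. Compound 4 `CC(C)NNc1nnc(-c2ccccc2Cl)s1` has not yet been measured in this assay. It differs from compound 3 by chloro in place of methyl on an aromatic carbon, the same change, at the same place, as from compound 1 to compound 2. The step of a 2.4-fold higher number from compound 3 to compound 4 (0.38 log units; beyond the scatter) is therefore expected to resemble the earlier one, because compound 2 sat at the limit of > 100 mg/kg in this assay, at which 1 of the 3 values shown sits. For compound 4 an estimate of 130 mg/kg, between 70 mg/kg and 300 mg/kg, is expected.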

Compound 4, dose for half-maximal effect: 50 mg/kg
Beside the measured number, compound 4's estimate is 2.6-fold (0.41 log units) above it; measured number outside the range, below it.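

Chloro in place of methyl on an aromatic carbon gives a 1.1-fold lower number from compound 3 to compound 4 (0.03 log units; within the scatter) in this assay, so on the core of compound 3 this change shows no effect beyond the scatter. Compound 2 stands at a limit of the assay, > 100 mg/kg, which is not a number. The step of an at least 2.0-fold lower number from compound 2 to compound 4 (0.30 log units; that floor lies within the scatter) therefore gives only a floor, and whether the change carries from one core to the other stays undecided: the same change on two cores in this assay, an at least 2.0-fold higher number (0.30 log units; that floor lies within the scatter) from compound 1 to compound 2 and a 1.1-fold lower number (0.03 log units; within the scatter) from compound 3 to compound 4; the limit leaves it open whether they differ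

The compounds shown leave open how fluoro, methoxy or trifluoromethyl on the same aromatic carbon would read in this assay. They also leave open whether a longer chain in place of isopropyl would shift the number on either core.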